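A Small Swap on the Outer Ring of Compound 2

The source may hold more compounds than are shown below. What is called first, only, known or untested is meant among the compounds shown, and "the series" means these compounds.

Of the compounds shown here, three of a shared core have been measured in a physicochemical assay for lipophilicity, read by HPLC, at pH 7.5; a lower number here means a more polar compound, a higher number a more lipophilic compound. Compound 1 `CC(C)(CC(N)=O)c1c(C#N)c(-c2ccc(Br)cc2)nc2cnccc12` gives 2.1 in this assay. Compound 2 `CC[C@@H](Nc1c(C#N)c(-c2ccc(-c3ccccc3OC)cc2)nc2cnccc12)C(N)=O` gives 2.7, and compound 3 `CCOc1ccccc1-c1ccc(-c2nc3cnccc3cc2C#N)cc1` gives 3.8. On these numbers compound 2 stands second highest of the three: compound 1 lies lower, a gap beyond the usual scatter, and compound 3 lies higher, again beyond the scatter. No two of the measured compounds differ in a single place, so none of these gaps can be tied to one change.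

Compound 4 `CC[C@@H](Nc1c(C#N)c(-c2ccc(-c3ccccc3N(C)C)cc2)nc2cnccc12)C(N)=O` has not yet been measured. It differs from compound 2 in one place: dimethylamino in place of methoxy on an aromatic carbon. Within the data shown here, no measured pair shows this change, so there is no step to lean on. The change adds one heavy atom and keeps the count of hydrogen-bond donors and acceptors unchanged, so the expected step in this assay from compound 2 to compound 4 is small and upward, a number 0.20 log units higher from compound 2 to compound 4 (within the scatter), likely within the scatter. The estimate for compound 4 in this assay is therefore 2.9, with a range from 2.5 to 3.3.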

Compound 4, distribution coefficient: 3.2
Compound 4: middle estimate off by 0.30 log units, on the low side; low and high end bracket the measured number.
By their numbers in this assay, from the lowest: compound 1; then compound 2; then compound 4; then compound 3.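

Among these compounds, compound 4 supplies the first comparison in this set that differs in one place: in this assay, dimethylamino in place of methoxy, on an aromatic carbon ortho to a large group, gives a number 0.50 log units higher from compound 2 to compound 4 (beyond the scatter). The earlier compounds shown here differed in several places at once, so their gaps could not be tied to any single change, whereas this one belongs to the swap from 2-methoxyphenyl to 2-(dimethylamino)phenyl alone. The reading at this position therefore responds to the swap beyond the scatter, even though the group that enters adds only one heavy atom and matches the group that leaves in its counts of hydrogen-bond donors and acceptors, and no measurement here bears on why the number moves.

This remains one pair with one side chain on the shared core, so it cannot show whether the same swap would give a similar step in a compound with another side chain. It also leaves open how this assay would respond at this position to a primary amine, a carboxylic acid or a longer alkoxy chain.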